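A few compounds are considered here, and "the series" means these few. Any claim that something is new, unique, unknown or untested is made for them only; others in the source may bear on it.

Compound 1 `COc1ccc(Cl)cc1C(=O)NCCC1CCN(S(=O)(=O)NC(=O)NC[C@H]2C[C@@H]3CC[C@@H]2O3)CC1` is one of two compounds that have been tested in a functional assay on the whole organism (blood) with Rattus norvegicus as the target, with stated times of 24 h and 1 h, at a dose of 5 mg/kg by the intraperitoneal route (a higher number here means a stronger effect of the compound at the dose given, a lower number a weaker effect), and in that setting compound 1 gives 27%. Compound 2 `Cc1ncsc1C(=O)NCCC1CCN(S(=O)(=O)NC(=O)NC[C@@H]2C[C@@H]3C=C[C@@H]2C3)CC1` carries a different amide group on the same core, and in this assay compound 2 gives 11%, the lower of the two numbers shown, with compound 1 standing higher by a gap that lies beyond the usual scatter of this kind of measurement.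

Compound 3 `O=C(NC[C@@H]1C[C@@H]2C=C[C@@H]1C2)NS(=O)(=O)N1CCC(CCNC(=O)c2cccc3c2OCCO3)CC1` has not yet been tested. It differs from compound 2 in one place: 2,3-dihydro-1,4-benzodioxin-5-yl in place of 4-methyl-1,3-thiazol-5-yl on a carbonyl carbon. Within the data shown here, no pair of measured compounds shows the effect of this exact exchange, so nothing measured speaks to its size directly. What can be said is that compound 1, whose amide also bears a six-membered aromatic ring, gives 27%, while compound 2 gives 11%.

On that basis an upward step of modest size is expected from compound 2 to compound 3 in this assay, a number 9 percentage points higher from compound 2 to compound 3 (within the scatter), though one that may not clear the scatter. For compound 3 the expected activity is 20%, with a range from 5% to 38%.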

Compound 3, a percentage reported as activity, at one dose (the size of the read-out at that dose, not a potency): 11%
The estimate for compound 3 lay 9 percentage points above the measured number; low and high end bracket the measured number.
By their numbers in this assay, from the lowest: compounds 2 and 3 (each within the scatter of the next); then compound 1.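

This first pair of compounds differing in one place shows that, in this assay, swapping the 4-methyl-1,3-thiazol-5-yl group of the amide for a 2,3-dihydro-1,4-benzodioxin-5-yl group gives no change at the digits printed from compound 2 to compound 3 (within the scatter) and so leaves the two amides unseparated. At this position, an entering group of 10 heavy atoms with a six-membered aromatic ring of carbon only and a six-membered non-aromatic ring therefore reads no differently at the dose given from a leaving group of 6 heavy atoms with one five-membered aromatic ring, with the count of hydrogen-bond acceptors the same on both sides. No measurement at hand offers an explanation for this result.

Compound 1 differs from compound 2 and from compound 3 in more than one place, so the compounds shown do not tell whether its amide group or its other end accounts for its number. They also leave open how this position would respond to a plain phenyl ring, a pyridine ring, or an amine or carboxylic acid on the amide ring, and whether any such group would move the read-out beyond the scatter.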